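The source may hold more compounds than are shown below. What is called first, only, known or untested is meant among the compounds shown, and "the series" means these compounds.

In a physicochemical assay for solubility (a higher number here means a more soluble compound, a lower number a less soluble compound), compound 1 `O=C1CC[C@@H](C(=O)N2CCC(NS(=O)(=O)c3cc(S(=O)(=O)c4ccccc4)ccc3C(F)(F)F)CC2)N1` gives 100000 nM and compound 2 `CC(=O)N1CCC[C@H]1C(=O)N1CCC(NS(=O)(=O)c2cc(S(=O)(=O)c3ccccc3)ccc2C(F)(F)F)CC1` gives 12500 nM as the lower of the two numbers. Within the data shown here, compound 3 `O=C([C@@H]1CCCN1C(=O)c1ccncc1)N1CCC(NS(=O)(=O)c2cc(S(=O)(=O)c3ccccc3)ccc2C(F)(F)F)CC1` keeps the core of compound 2 but carries pyridin-4-yl in place of methyl on a carbonyl carbon and has no measurement yet. Among the measured compounds shown here, only one measured step bears on this change, namely an 8.0-fold lower number from compound 1 to compound 2 (0.90 log units; beyond the scatter) for a different swap, so it is a loose guide. A smaller drop in this assay is therefore expected, with an estimated 2.5-fold lower number from compound 2 to compound 3 (0.40 log units; beyond the scatter) as its likely size. For compound 3 the expected value is 5000 nM within an estimated range of 1500 nM to 20000 nM for now.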

Compound 3, solubility: 100000 nM
The estimate for compound 3 lay 20-fold (1.30 log units) below the measured number; the measured number lies above the stated range.
By their numbers in this assay, from the lowest: compound 2; then compounds 1 and 3 (each within the scatter of the next).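

In this assay, pyridin-4-yl in place of methyl on a carbonyl carbon gives an 8.0-fold higher number from compound 2 to compound 3 (0.90 log units; beyond the scatter). This shows that the group at this position can move the number upward, and that going from one heavy atom to six does not have to bring it down. No measurement at hand explains the rise. From the compounds shown here alone, it remains open whether the ring itself or its nitrogen goes with the higher number, which phenyl at the same place could separate. Going by these compounds, how an amine or a carboxylic acid would behave there is also open.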